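Halogen swap on the anilino ring, second instance

This account rests on a few compounds, and the source may have more. Where it says the series, first, only, none or still open, it means among the compounds named here.

Compound 1 `O=S(=O)(c1ccccc1)c1nc2ccccc2nc1Nc1ccc(F)cc1`, compound 2 `O=S(=O)(c1ccccc1)c1nc2ccccc2nc1Nc1ccc(Cl)cc1` and compound 3 `Cc1ccc(S(=O)(=O)c2nc3ccccc3nc2Nc2ccc(F)cc2)cc1` are measured; compound 4 `Cc1ccc(S(=O)(=O)c2nc3ccccc3nc2Nc2ccc(Cl)cc2)cc1` is not yet. In a functional assay on HCT-116 cells (Homo sapiens) for cytotoxicity, read by MTT assay, with a stated time of 72 h (on this read-out lower numbers stand for stronger inhibition and higher numbers for weaker inhibition), compound 1 gives 5190 nM. In this assay compound 2 gives 2000 nM, and compound 3 gives 10500 nM in this assay, the highest of the three numbers.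

Two single changes are measured. One, (chloro in place of fluoro on an aromatic carbon), brings a 2.6-fold lower number from compound 1 to compound 2 (0.41 log units; beyond the scatter). The other, (methyl in place of hydrogen on an aromatic carbon), brings a 2.0-fold higher number from compound 1 to compound 3 (0.31 log units; beyond the scatter); this is also how the core of compound 3 differs from the core of compound 1. Compound 2 and compound 3 differ in two places at once, so their values are set side by side only as they stand.

Compound 4 is reached from compound 3 by chloro in place of fluoro on an aromatic carbon, the same change that turns compound 1 into compound 2; among the compounds shown it occurs twice, and the place reads the same word for word in both pairs. Among the compounds with values here, only one measured instance exists, so the expectation rests on that single step and on the spread between compound 1 and compound 3. For compound 4 a step of a 2.6-fold lower number from compound 3 to compound 4 (0.42 log units; beyond the scatter) in this assay is expected, because the same change gave a 2.6-fold lower number from compound 1 to compound 2 (0.41 log units; beyond the scatter). The estimated value for compound 4 in this assay is 4000 nM, with the expected range running from 2000 nM to 8000 nM.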

Compound 4, half-maximal inhibitory concentration: 2050 nM
The estimate for compound 4 lay 2.0-fold (0.29 log units) above the measured number; the range from low to high includes it.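

In this assay, chloro in place of fluoro again gives a lower number, now as a 5.1-fold lower number from compound 3 to compound 4 (0.71 log units; beyond the scatter), and the two steps on the two cores cannot be told apart in size: the same change on two cores in this assay, a 2.6-fold lower number (0.41 log units; beyond the scatter) from compound 1 to compound 2 and a 5.1-fold lower number (0.71 log units; beyond the scatter) from compound 3 to compound 4, 2.0-fold (0.30 log units) apart, within the scatter of two such steps. Methyl in place of hydrogen on an aromatic carbon reads as a 1.0-fold higher number from compound 2 to compound 4 (0.01 log units; within the scatter), which lies within the scatter, and this step also cannot be told apart from its counterpart on the fluoro compounds: the same change on two cores in this assay, a 2.0-fold higher number (0.31 log units; beyond the scatter) from compound 1 to compound 3 and a 1.0-fold higher number (0.01 log units; within the scatter) from compound 2 to compound 4, 2.0-fold (0.30 log units) apart, within the scatter of two such steps. The halogen change therefore carries over in direction between the two cores shown, but a single pair on each core does not show that it would do so on any other core, nor does it establish that the step is larger on one core than on the other, or that the methyl and halogen changes depend on each other.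

The compounds shown leave open whether the trend extends beyond fluoro and chloro to a bromo, methoxy or trifluoromethyl group in the same place. They also leave open how an amine or a carboxylic acid on either aromatic ring would read, and whether the halogen step holds in cells other than those tested here.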